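Swapping the thiazole aryl group: from methylsulfonylphenyl to naphthyl

The source may report more compounds than this note shows. Statements on the series, on what has been measured and on what is new or still open speak of the compounds shown alone.

Measured compounds:
compound 1, `N#Cc1ccc(-c2csc(N3N=C(c4ccc(N5CCCCC5)cc4)CC3c3ccc(Cl)cc3)n2)cc1`, 11200 nM
compound 2, `CS(=O)(=O)c1ccc(-c2csc(N3N=C(c4ccc(N5CCCCC5)cc4)CC3c3ccc(Cl)cc3)n2)cc1`, > 100000 nM

Compound 1 gives 11200 nM in a functional assay on A549 cells (Homo sapiens) for antiproliferative activity, read by MTT assay, with a stated time of 72 h; on this read-out lower numbers stand for stronger inhibition and higher numbers for weaker inhibition. For compound 2 the value of > 100000 nM is a limit of the assay, not a number; this is the situation described by the limit of > 100000 nM in this assay, at which 1 of the 2 values shown sits. Going by the values given here, the step of an at least 8.9-fold higher number from compound 1 to compound 2 (0.95 log units; beyond the scatter) is the only measured comparison, and it is beyond the scatter. Compound 3, `Clc1ccc(C2CC(c3ccc(N4CCCCC4)cc3)=NN2c2nc(-c3ccc4ccccc4c3)cs2)cc1`, differs from compound 2 by naphthalen-2-yl in place of 4-(methylsulfonyl)phenyl on an aromatic carbon. The measured step bears only indirectly on this change, since it removes the methylsulfonyl group altogether rather than returning to cyano. Because compound 1 gives 11200 nM with a different group at the same place, a number in the region of compound 1 is expected for compound 3, though with wide uncertainty. Compound 3 is therefore estimated at 15000 nM, within 3000 nM to 100000 nM, meaning an expected step of an at least 6.6-fold lower number from compound 2 to compound 3 (0.82 log units; beyond the scatter).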

Compound 3, half-maximal inhibitory concentration: > 100000 nM
Compound 3: a limit, no number; the forecaster's own chance of this, stated with the estimate: 25%; middle value at least 6.6-fold (0.82 log units) from the limit.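

Replacing 4-cyanophenyl with naphthalen-2-yl gives an at least 8.9-fold higher number from compound 1 to compound 3 (0.95 log units; beyond the scatter) in this assay, so a second replacement on this aromatic carbon also weakens the inhibition. The weakening is therefore not confined to 4-(methylsulfonyl)phenyl: a group with hydrogen-bond acceptors and a group of carbon only both end at the same limit, which is not a number: the limit of > 100000 nM in this assay, at which 2 of the 3 values shown sit. Compound 2 and compound 3 both carry limits, and the step between them cannot be read.

As far as these compounds go, whether a plain phenyl group, or a phenyl group bearing an amine or a carboxylic acid, would match or improve on compound 1 stays open. With only three groups shown at this place, no general rule can be drawn about what the position accepts.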